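Aryl amide variation on the shared core: working notes

The source may hold more compounds than are shown below. What is called first, only, known or untested is meant among the compounds shown, and "the series" means these compounds.

Compound 1 `CC(=O)/N=C1\NC2(CCCCO2)CCS1` gives 3.1 mg/kg in a functional assay on the whole organism (strain CF-1) with Mus musculus as the target, in the writhing test, with a stated time of 15 min; on this read-out higher numbers stand for an effect only at larger amounts of compound and lower numbers for an effect already at smaller amounts.
Compound 2 `O=C(/N=C1\NC2(CCCCO2)CCS1)c1cccc(F)c1` gives 9.2 mg/kg in this assay.

Among the measured compounds shown here, compound 2 has the highest number of the two measured so far. Its nearest neighbour is compound 1, and the step of a 3.0-fold higher number from compound 1 to compound 2 (0.47 log units; beyond the scatter) lies beyond the scatter, so the two compounds are genuinely distinguished on this read-out. The next step leads to compound 3 `Cc1ccc(C(=O)/N=C2\NC3(CCCCO3)CCS2)cc1` and consists of 4-methylphenyl in place of 3-fluorophenyl on a carbonyl carbon.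

For the measured compounds named here, no measured step bears directly on this exchange. Going by the values given here, the only recorded step, a 3.0-fold higher number from compound 1 to compound 2 (0.47 log units; beyond the scatter), replaces methyl with 3-fluorophenyl at the same carbonyl carbon and is a change of a different kind; it shows only that an aryl amide at this position is tolerated in the whole-animal read-out. It gives no basis for a direction when one aryl group is swapped for another of the same size. Without a comparable step, the expectation is for a change within the scatter, a 1.0-fold lower number from compound 2 to compound 3 (0.01 log units; within the scatter), with the measured value of compound 2 as the anchor. Compound 3 is therefore expected to give about 9 mg/kg, within a range of 4 mg/kg to 22 mg/kg.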

Compound 3, dose for half-maximal effect: 60 mg/kg
For compound 3 the middle estimate is 6.7-fold (0.82 log units) below the measured one; measured number outside the range, above it.
By their numbers in this assay, from the lowest: compound 1; then compound 2; then compound 3.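

In this assay the aryl group on this carbonyl carbon turns out not to be a neutral choice: a 6.5-fold higher number from compound 2 to compound 3 (0.81 log units; beyond the scatter), although 3-fluorophenyl and 4-methylphenyl match in heavy-atom count and each holds one six-membered aromatic ring of carbon only. Among the compounds shown here, the position therefore distinguishes between two aryl groups of equal count, which the earlier pair, with its single exchange of methyl for an aryl group, could not show. Measured against the methyl group, the new exchange gives a 19-fold higher number from compound 1 to compound 3 (1.29 log units; beyond the scatter), so compound 1 keeps the lowest number of the three and the cost of an aryl group at this carbon depends on which aryl group it is; nothing available explains the difference between the two aryl groups.

The exchange alters both the substituent and its numbered place on the ring, and the compounds shown do not separate these two changes, which 4-fluorophenyl or 3-methylphenyl at the same carbon would begin to do. Also open, on these data alone, is how a plain phenyl group, or a longer chain in place of methyl, would stand.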